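Phenoxy to 4-Methoxyphenyl: Expected Permeability of Compound 3

This account rests on a few compounds, and the source may have more. Where it says the series, first, only, none or still open, it means among the compounds named here.

Measured compounds:
Compound 1, `COc1ccc(F)cc1CNCCCNc1ccnc2cc(Cc3ccc(C#N)cc3)ccc12`, in an ADME assay for permeability, using PAMPA, with a stated time of 30 min, at pH 7.4 (on this read-out higher numbers stand for higher permeability and lower numbers for lower permeability), compound 1 gives 23 10^-6 cm/s.
Compound 2, `COc1cccc(CNCCCNc2ccnc3cc(Oc4ccccc4)ccc23)c1O`, in this assay compound 2 gives 317 10^-6 cm/s.

Compound 2 stands highest of the two numbers in this assay. Its nearest neighbour is compound 1, whose lower number lies beyond the usual scatter of repeated measurements, so the two compounds are clearly separated on this read-out. For the measured compounds named here, no single-point step between compound 1 and compound 2 is available, as they differ in more than one place, and nothing more can be said of the pair than what the two values show.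

Compound 3, `COc1ccc(-c2ccc3c(NCCCNCc4cccc(OC)c4O)ccnc3c2)cc1`, is not yet measured. It differs from compound 2 in one place: 4-methoxyphenyl in place of phenoxy on an aromatic carbon. The rest of the molecule is unchanged. With only compound 2 as a direct anchor, the step from compound 2 to compound 3 is expected to be small, at most a modest decrease that may fall within the scatter, a 1.4-fold lower number from compound 2 to compound 3 (0.16 log units; within the scatter). On that basis compound 3 is estimated at 220 10^-6 cm/s in this assay, with a range from 70 10^-6 cm/s to 500 10^-6 cm/s.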

Compound 3, apparent permeability: 237 10^-6 cm/s
Estimate against measurement, compound 3: 1.1-fold (0.03 log units) below; the measured number falls inside the stated range.
By their numbers in this assay, from the lowest: compound 1; then compounds 3 and 2 (each within the scatter of the next).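

In this assay, for the compounds shown here, placing 4-methoxyphenyl where phenoxy stood on this aromatic carbon gives a 1.3-fold lower number from compound 2 to compound 3 (0.13 log units; within the scatter), the only single-place step so far, and it shows that this position takes the exchange with no difference that can be told from the scatter. The leaving group of 7 heavy atoms and the entering group of 8 each hold one six-membered aromatic ring of carbon only, and on this read-out the two compounds stand level within the scatter, so this one exchange at this position does not separate them. No measurement is at hand that would explain this result.

As far as these compounds go, whether this position would stay as undemanding with an amine or a carboxylic acid on the same aromatic carbon remains open, since both groups seen there so far are uncharged and carry a carbon-only aromatic ring. What lies behind the gap to compound 1 also stays open, as compound 1 differs from the other two compounds in more than one place and no single change can be held to account for it.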